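Shortening the ester chain on a cytidine nucleoside

This account rests on a few compounds, and the source may have more. Where it says the series, first, only, none or still open, it means among the compounds named here.

Three esters of the same nucleoside core have been tested in a functional assay on HeLa cells (Homo sapiens) for cytotoxicity, read by cell counting, with a stated time of 48 h; a lower number here means that less compound is needed, a higher number that more compound is needed for the effect. Compound 1 `CCCC(=O)OC[C@H]1O[C@@H](n2ccc(N)nc2=O)[C@@H](O)[C@@H]1OC(=O)CCC` carries two short butanoyl esters and gives 0.11 ug/mL. Compound 2 `CCCCCCCCCCCC(=O)O[C@H]1[C@H](O)[C@H](n2ccc(N)nc2=O)O[C@@H]1CO` carries a single long dodecanoyl ester and gives 0.08 ug/mL. Compound 3 `CCCCCCCC(=O)O[C@H]1[C@H](O)[C@H](n2ccc(N)nc2=O)O[C@@H]1CO` carries a single octanoyl ester at the same position and gives 0.1 ug/mL. The number for compound 3 sits close to those of compound 1 and compound 2, and every gap among these three values lies within the usual scatter, so none of them can be called more or less potent than another.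

Compound 4 `CCCC(=O)O[C@H]1[C@H](O)[C@H](n2ccc(N)nc2=O)O[C@@H]1CO` is the next member of the series: its difference from compound 3 is hydrogen in place of butyl on a saturated chain carbon, three bonds along the chain from a carbonyl carbon. For the measured compounds named here, the only measured step of the same kind is the one from compound 2 to compound 3, in which a 1.3-fold higher number from compound 2 to compound 3 (0.10 log units; within the scatter) was seen. That step, cutting the same number of carbons from the chain, moved the number by an amount inside the scatter, and compound 1, with butanoyl esters, also sits in the same range. A step of about the same size is therefore expected here, a 1.2-fold higher number from compound 3 to compound 4 (0.08 log units; within the scatter), with no change beyond the scatter. Compound 4 is estimated to give 0.12 ug/mL, within a range of 0.06 ug/mL to 0.3 ug/mL.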

Compound 4, concentration for half-maximal effect: 0.11 ug/mL
For compound 4 the middle estimate is 1.1-fold (0.04 log units) above the measured one, within the range that was stated.
By their numbers in this assay, from the lowest: compounds 2, 3, 1 and 4 (each within the scatter of the next).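

In this assay, the chain on this ester can lose butyl at the carbon three bonds along from the carbonyl carbon, giving a 1.1-fold higher number from compound 3 to compound 4 (0.04 log units; within the scatter) as the result, and the same cut that removes octyl gives a 1.4-fold higher number from compound 2 to compound 4 (0.14 log units; within the scatter) as its result, so the short butanoyl ester stays within the scatter of both longer esters. The earlier compounds had shown this only for dodecanoyl and octanoyl, while the new result extends the flat stretch down to butanoyl. Putting hydrogen in place of propylcarbonyl on an oxygen on a saturated carbon also gives no change at the digits printed from compound 1 to compound 4 (within the scatter) as its result, so a second butanoyl ester on the shared core makes no readable difference here, and nothing available offers an explanation for this flat picture.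

As far as these compounds go, it remains open whether the number would stay in this range with a chain longer than dodecanoyl, or with an amine or a carboxylic acid at the far end of the chain. From the compounds shown here alone, it is equally open what an amide in place of the ester, or a plain hydroxyl with no acyl chain at all, would do at this position.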